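Nitro for Methoxy on a Shared Core

The source may hold more compounds than are shown below. What is called first, only, known or untested is meant among the compounds shown, and "the series" means these compounds.

Measured so far:
compound 1, `CC(C)(C)OC(=O)/C=C1/C(=O)N(Cc2ccccc2)c2ccccc21`, 78.4%
compound 2, `CN1C(=O)/C(=C/C(=O)OC(C)(C)C)c2ccccc21`, 77.8%
compound 3, `COc1ccc2c(c1)/C(=C\C(=O)OC(C)(C)C)C(=O)N2`, 78.7%

All three compounds were tested in a functional assay on SW480 cells (Homo sapiens) for inhibition, read by CCK-8 assay, with a stated time of 72 h, tested at 20 uM; on this read-out lower numbers stand for less inhibition of growth and higher numbers for more inhibition of growth at the one concentration tested. Their numbers sit on top of one another: compound 3 is nominally at the top of the three, but its gaps to compound 1 and to compound 2 are both within the scatter, so none of the three can be told apart.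

Compound 4, `CC(C)(C)OC(=O)/C=C1/C(=O)Nc2ccc([N+](=O)[O-])cc21`, is compound 3 with nitro in place of methoxy on an aromatic carbon. Among the compounds with values here, only one measured step exists, and it concerns a different position: a number 0.6 percentage points lower from compound 1 to compound 2 (within the scatter), a change at the ring nitrogen that left the number unchanged beyond the scatter. Within the data shown here, no measured step alters a substituent on the aromatic ring of the core, so there is no direct precedent for the nitro-for-methoxy swap. What the shown compounds do say is that this core has so far held its number through every change tried.

Compound 4 is therefore expected to give 77%, with a range from 62% to 88%. The expected step of a number 1.7 percentage points lower from compound 3 to compound 4 (within the scatter) is estimated to be none beyond the scatter.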

Compound 4, percent growth inhibition at one concentration: 77.9%
Estimate against measurement, compound 4: 0.9 percentage points below; the range from low to high includes it.
By their numbers in this assay, from the lowest: compounds 2, 4, 1 and 3 (each within the scatter of the next).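

In this assay, nitro in place of methoxy on the aromatic carbon gives a number 0.8 percentage points lower from compound 3 to compound 4 (within the scatter) and so leaves the number where it was within the scatter. Within the data shown here, this is the first measured change on the aromatic ring of the shared core, whereas the earlier step concerned only the ring nitrogen. The number therefore holds at this position for a swap between two groups that differ in their atoms and in their counts of heavy atoms and hydrogen-bond acceptors. No measurement at hand says why the number holds here.

As far as these compounds go, whether an amine or a carboxylic acid on this same aromatic carbon would also hold the number remains open. Also open, from the compounds shown here alone, is whether compound 3 and compound 4 would still match at concentrations other than the single one tested.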